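The source may report more compounds than this note shows. Statements on the series, on what has been measured and on what is new or still open speak of the compounds shown alone.

Measured in a functional assay on KB cells (Homo sapiens) for antiproliferative activity, read by sulforhodamine B assay, with a stated time of 3 days; on this read-out higher numbers stand for an effect only at larger amounts of compound and lower numbers for an effect already at smaller amounts:
Compound 1 `CCCc1ccc(-c2cc(=O)c3c(o2)C(CC)(CC)C(=O)C(CC)=C3O)cc1`: > 53 uM, a limit
Compound 2 `CCC1=C(O)c2c(oc(-c3ccc(OC)cc3)cc2=O)C(CC)(CC)C1=O`: 17.7 uM
Compound 3 `CCC1=C(O)c2c(oc(-c3ccc(F)cc3)cc2=O)C(CC)(CC)C1=O`: 33 uM

Compound 3 gives 33 uM and sits within the scatter of compound 2, which gives 17.7 uM. The step between them is a 1.9-fold higher number from compound 2 to compound 3 (0.27 log units; within the scatter). Compound 1 is known only as a limit, > 53 uM.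

Compound 4 `CCC1=C(O)c2c(oc(-c3cccc(OC)c3)cc2=O)C(CC)(CC)C1=O` has 3-methoxyphenyl in place of the 4-fluorophenyl of compound 3 on an aromatic carbon: 3-methoxyphenyl in place of 4-fluorophenyl on an aromatic carbon. Within the data shown here, three measured steps bear on this change. The closest is the exchange between methoxy and fluoro, a 1.9-fold higher number from compound 2 to compound 3 (0.27 log units; within the scatter), which does not go beyond the scatter. The two steps away from propyl are an at least 2.9-fold lower number from compound 1 to compound 2 (0.47 log units; beyond the scatter) and an at least 1.6-fold lower number from compound 1 to compound 3 (0.20 log units; that floor lies within the scatter), and both start from a limit, so they give only floors. Only the methoxy floor clears the scatter. Among the measured compounds shown here, no measured step shows what moving the methoxy group around the aromatic ring does, which leaves the estimate wide.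

In this assay, a small shift towards the value of compound 2 is therefore expected, but nothing clearly beyond the scatter. The expected step is a 1.5-fold lower number from compound 3 to compound 4 (0.18 log units; within the scatter). The estimated value for compound 4 is 22 uM, with an expected range from 9 uM to 50 uM.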

Compound 4, concentration for half-maximal effect: 13.3 uM
Compound 4: the middle estimate sits 1.7-fold (0.22 log units) above what was measured; measured number inside the range.
By their numbers in this assay, from the lowest: compounds 4, 2 and 3 (each within the scatter of the next, the first and the last beyond it). At a limit, above all of these: compound 1.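

In this assay, the exchange of 4-methoxyphenyl for 3-methoxyphenyl gives a 1.3-fold lower number from compound 2 to compound 4 (0.12 log units; within the scatter), so the two placings of the methoxy group on the aromatic ring cannot be told apart on this read-out. Against 4-fluorophenyl, 3-methoxyphenyl gives a 2.5-fold lower number from compound 3 to compound 4 (0.39 log units; beyond the scatter), which is the first step between a methoxy-bearing and a fluoro-bearing compound to clear the scatter, although the exchange with 4-methoxyphenyl did not. Against 4-propylphenyl, the same group gives an at least 3.9-fold lower number from compound 1 to compound 4 (0.60 log units; beyond the scatter), a floor and not a measured size, as it starts from the limit of compound 1: the limit of > 53 uM in this assay, at which 1 of the 4 values shown sits.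

The compounds shown leave open whether fluoro or propyl would also tolerate a move around the aromatic ring, and what an amine or a carboxylic acid would do in place of the methoxy group. On these data alone, the rest of the shared core is the same in all four compounds, so the effect of a longer chain on that core also remains open.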